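Swapping Butyl for Phenyl on Two Related Cores

The compounds below may be only part of what the source reports. "The series", "measured", "known", "first", "only" and "open" are said of these compounds alone.

Compound 1 `CCCCCCCCS(=O)(=O)Nc1cc(-c2ccc(CCCC)cc2)ccc1C(=O)O` and compound 3 `CCCCCCCCS(=O)(=O)Nc1ccc(-c2ccc(CCCC)cc2)cc1C(=O)O` are made of the same atoms joined differently; the difference between the two cores is not broken down here. In an assay on mitochondria (strain BALB/c) for inhibition of glycerol-3-phosphate acyltransferase 1, mitochondrial (Mus musculus), read by scintillation counting, with a stated time of 10 min (on this read-out higher numbers stand for weaker inhibition and lower numbers for stronger inhibition), compound 1 gives 15700 nM, and compound 3 gives 9000 nM. Compound 2 `CCCCCCCCS(=O)(=O)Nc1cc(-c2ccc(-c3ccccc3)cc2)ccc1C(=O)O` differs from compound 1 by one change, (phenyl in place of butyl on an aromatic carbon). In this assay compound 2 gives 13500 nM, so the change made a 1.2-fold lower number from compound 1 to compound 2 (0.07 log units; within the scatter). Compound 4 `CCCCCCCCS(=O)(=O)Nc1ccc(-c2ccc(-c3ccccc3)cc2)cc1C(=O)O`, not yet measured, carries the same change relative to compound 3: phenyl in place of butyl on an aromatic carbon. The place of the change is described in the same words for both pairs, so the change counts as the same one on a different core. For compound 4 a step of about the earlier size is expected, a 1.2-fold lower number from compound 3 to compound 4 (0.08 log units; within the scatter), because the same change gave a 1.2-fold lower number from compound 1 to compound 2 (0.07 log units; within the scatter). Within the data shown here, compound 4 is therefore estimated at 7500 nM in this assay, most likely between 3500 nM and 16000 nM, with the single earlier example as the only basis.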

Compound 4, half-maximal inhibitory concentration: 29100 nM
The estimate for compound 4 lay 3.9-fold (0.59 log units) below the measured number; the measured number lies above the stated range.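

In this assay, phenyl in place of butyl on an aromatic carbon gave a 3.2-fold higher number from compound 3 to compound 4 (0.51 log units; beyond the scatter), which means weaker inhibition on this core, whereas on the core of compound 1 the same change gave no step beyond the scatter. Set side by side, the two results do not agree: the same change on two cores in this assay, a 1.2-fold lower number (0.07 log units; within the scatter) from compound 1 to compound 2 and a 3.2-fold higher number (0.51 log units; beyond the scatter) from compound 3 to compound 4, 3.8-fold (0.58 log units) apart, beyond the scatter of two such steps. So the size of this change on one core did not predict its size on the other in this series, but with only one pair per core this does not show why the cores differ or how the change would behave on a further core.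

The compounds shown leave open whether the step on the core of compound 3 is particular to phenyl or would also appear with another group on that aromatic carbon, such as a longer chain like hexyl or a saturated cyclohexyl ring. They also leave open whether a small group, such as methoxy or a single chlorine atom, would behave alike on both cores.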